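Oxazole piperidine amides: kinetic solubility, aryl swap

This account rests on a few compounds, and the source may have more. Where it says the series, first, only, none or still open, it means among the compounds named here.

Measured so far in a physicochemical assay for solubility, in phosphate buffer, measured as kinetic solubility, at pH 7.4; a lower number here means a less soluble compound, a higher number a more soluble compound:
compound 1 `Cc1ccc(C)c(-c2nc(CN3CCC(C(=O)NCCCN4C[C@H](C)C[C@H](C)C4)CC3)c(C)o2)c1` gives 56.1 ug/mL
compound 2 `CCCN(CCC)CCNC(=O)C1CCN(Cc2nc(-c3ccccc3C)oc2C)CC1` gives > 65 ug/mL, which is a limit of the assay and not a number
compound 3 `Cc1cccc(Cl)c1-c1nc(CN2CCC(C(=O)NCCCN3CCC(C(C)C)CC3)CC2)c(C)o1` gives > 76 ug/mL, also a limit of the assay and not a number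

Going by the values given here, compound 1 therefore stands as the only compound of the three with a numerical solubility in this assay; the other two values sit at the limit of > 65 ug/mL in this assay, at which 1 of the 3 values shown sits, and at the limit of > 76 ug/mL in this assay, at which 1 of the 3 values shown sits, so no comparison of order among the three is possible, and no step between measured compounds can be drawn.

The compound to be measured next is compound 4 `COc1cccc(Cl)c1-c1nc(CN2CCC(C(=O)NCCCN3C[C@H](C)C[C@H](C)C3)CC2)c(C)o1`. It differs from compound 1 in one place: 2-chloro-6-methoxyphenyl in place of 2,5-dimethylphenyl on an aromatic carbon. The rest of the shared core, the piperidine amide and the dimethylpiperidine chain are unchanged.

Among the compounds with values here, no measured step supports a direction for this change. In this assay the expectation for compound 4 is a step of a 1.1-fold lower number from compound 1 to compound 4 (0.05 log units; within the scatter), which is within the usual scatter, with no clear shift either way. The estimate for compound 4 is therefore 50 ug/mL, with a range from 25 ug/mL to 100 ug/mL.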

Compound 4, solubility: > 76 ug/mL
Compound 4 ended at the assay's limit (the forecaster's own chance of this, stated with the estimate: 30%); middle value at least 1.5-fold (0.18 log units) from the limit.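

In this assay compound 4 gives > 76 ug/mL, which is a limit of the assay and not a number. Going by these compounds alone, the first step at this position is an at least 1.3-fold higher number from compound 1 to compound 4 (0.13 log units; that floor lies within the scatter), so 2-chloro-6-methoxyphenyl, which brings chlorine and a hydrogen-bond acceptor onto the aromatic ring, shows no loss against the carbon-only 2,5-dimethylphenyl, while the floor of the step leaves the order of the two compounds unsettled. With the piperidine amide and the dimethylpiperidine chain unchanged, this reading belongs to the aryl swap alone, and compound 4 now shares its reading with one other compound: the limit of > 76 ug/mL in this assay, at which 2 of the 4 values shown sit.

Within the data shown here, the size of the step beyond its floor stays open, and the single swap cannot separate what the chlorine and the methoxy each contribute. Also open, as far as these compounds go, is how a more strongly ionisable group on this aromatic ring, such as an aminomethyl group or a carboxylic acid in place of the methoxy, would read in this assay on the same unchanged chain.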